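From Azetidinylcarbonyl to Carbamoyl: Expectation for Compound 3

The source may hold more compounds than are shown below. What is called first, only, known or untested is meant among the compounds shown, and "the series" means these compounds.

Compound 1 `Cc1ccccc1C(=O)Nc1ccc(S(=O)(=O)NC2CCN(C(=O)CCCN)CC2)c2ccccc12` gives 1.6 nM in an assay on L1.2 cells for binding affinity to C-C chemokine receptor type 8 (Homo sapiens); on this read-out higher numbers stand for weaker inhibition and lower numbers for stronger inhibition.
Compound 2 `Cc1ccccc1C(=O)Nc1ccc(S(=O)(=O)NC2CCN(C(=O)C3CNC3)CC2)c2ccccc12` gives 1.5 nM in this assay.

Compound 2 carries the lowest of the two numbers, though its nearest neighbour, compound 1, sits within the scatter of it, so the two cannot be ordered. Compound 3 `Cc1ccccc1C(=O)Nc1ccc(S(=O)(=O)NC2CCN(C(N)=O)CC2)c2ccccc12` differs from compound 2 by amino in place of azetidin-3-yl on a carbonyl carbon. For the measured compounds named here, the only measured step that touches this position, a 1.1-fold lower number from compound 1 to compound 2 (0.03 log units; within the scatter), replaced one amine-bearing group on the carbonyl carbon with another and changed nothing beyond the scatter. Going by the values given here, no measured step removes the ring and leaves only the amino group, so the bearing of that step on compound 3 is indirect. The expected outcome is a step of a 2.0-fold higher number from compound 2 to compound 3 (0.30 log units; within the scatter), at most a modest weakening. Compound 3 is therefore estimated at 3 nM in this assay, with a range from 1 nM to 10 nM.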

Compound 3, inhibition constant: 243 nM
Beside the measured number, compound 3's estimate is 81-fold (1.91 log units) below it; measured number outside the range, above it.
By their numbers in this assay, from the lowest: compounds 2 and 1 (each within the scatter of the next); then compound 3.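

In this assay, the group on the carbonyl carbon turns out to matter a great deal: replacing either substituent with amino gives a 160-fold higher number from compound 2 to compound 3 (2.21 log units; beyond the scatter) and a 150-fold higher number from compound 1 to compound 3 (2.18 log units; beyond the scatter), both large. The earlier exchange of 3-aminopropyl for azetidin-3-yl had shown only that a chain and a four-membered ring can stand in for each other on this carbonyl carbon, not that the position tolerates change in general. No measurement shown here gives a reason for the loss.

As far as these compounds go, it remains open whether a methyl group or an all-carbon chain on the carbonyl carbon would keep the low numbers of compound 1 and compound 2, or whether a short aminomethyl group would. The compounds shown therefore cannot tell whether the amine nitrogen or the carbon atoms of these groups account for the difference.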